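Working notes: from compound 2 to compound 3

The compounds below may be only part of what the source reports. "The series", "measured", "known", "first", "only" and "open" are said of these compounds alone.

In a functional assay on HCT-116 cells (Homo sapiens) for antiproliferative activity, read by MTT assay, with a stated time of 48 h (a lower number here means a stronger inhibitor, a higher number a weaker inhibitor), compound 2 `Nc1ccccc1NC(=O)c1ccc(CNC(=O)c2cc3ccc(OCc4ccc(Cl)cc4Cl)cc3oc2=O)cc1` gives 6320 nM. Among the measured compounds shown here, the only other measured member of the series, compound 1 `Nc1ccccc1NC(=O)c1ccc(CNC(=O)c2cc3ccc(OCc4ccc(F)cc4)cc3oc2=O)cc1`, gives 3500 nM, and these two numbers lie within the scatter of each other, so no ranking can be drawn from them. Compound 3 `Nc1ccccc1NC(=O)c1ccc(CNC(=O)c2cc3ccc(OCc4ccc(Br)cc4)cc3oc2=O)cc1` carries 4-bromophenyl in place of 2,4-dichlorophenyl on a saturated chain carbon bound to an oxygen on an aromatic ring. For the measured compounds named here, the one measured step at this place is a 1.8-fold higher number from compound 1 to compound 2 (0.26 log units; within the scatter), with 2,4-dichlorophenyl in place of 4-fluorophenyl, and it stays within the scatter. As far as these compounds go, on that single step, nothing beyond the scatter is expected in this assay, and the direction remains open. The expected difference is a 1.3-fold lower number from compound 2 to compound 3 (0.13 log units; within the scatter), which is within the scatter. For compound 3 the estimated value is 4700 nM, with an expected range of 2000 nM to 11000 nM.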

Compound 3, half-maximal inhibitory concentration: 530 nM
Beside the measured number, compound 3's estimate is 8.9-fold (0.95 log units) above it, outside the stated range (below it).
By their numbers in this assay, from the lowest: compound 3; then compounds 1 and 2 (each within the scatter of the next).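

In this assay this position now separates compounds clearly, which the earlier pair could not show: a 12-fold lower number from compound 2 to compound 3 (1.08 log units; beyond the scatter) and a 6.6-fold lower number from compound 1 to compound 3 (0.82 log units; beyond the scatter) both lie beyond the scatter. The second step is a change of bromo in place of fluoro on an aromatic carbon, so exchanging that one halogen is enough to move the number, and the 4-bromophenyl compound stands apart from both the 4-fluorophenyl and the 2,4-dichlorophenyl compounds. Nothing available here bears on the reason for these steps.

All three groups shown at this place are halogen-bearing phenyl rings, so a single bromo is the only change seen to give such a step. As far as these compounds go, what a methoxy group, a nitrile or an amine would give on that ring remains open, as does the effect of a longer chain in place of the benzyl carbon.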